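A few compounds are considered here, and "the series" means these few. Any claim that something is new, unique, unknown or untested is made for them only; others in the source may bear on it.

In an assay on SK-N-MC cells for inhibition of Neuropeptide Y receptor type 1 (Homo sapiens) (on this read-out lower numbers stand for stronger inhibition and higher numbers for weaker inhibition), compound 3 `COC(=O)C1=C(C)N=C(C)/C(=C(/O)OC)C1c1cccc(NC(=O)NCCNC2CCN(c3ccccc3C)CC2)c1` gives 4 nM, the lowest of the three numbers recorded so far. Compound 1 `COC(=O)C1=C(C)N=C(C)/C(=C(/O)OC)C1c1cccc(N/C(=N/CCNC2CCN(c3ccccc3)CC2)NC#N)c1` gives 10 nM and compound 2 `COC(=O)C1=C(C)N=C(C)/C(=C(/O)OC)C1c1cccc(N/C(=N/CCNC2CCN(c3ccccc3OC(F)(F)F)CC2)NC#N)c1` gives 28 nM, and both lie beyond the scatter from compound 3. Compound 4 `COC(=O)C1=C(C)N=C(C)/C(=C(/O)OC)C1c1cccc(NC(=O)NCCNC2CCN(c3ccccc3SC)CC2)c1` has not yet been measured. It differs from compound 3 in one place: methylsulfanyl in place of methyl on an aromatic carbon. Within the data shown here, only one measured step touches a change on that same six-membered ring, namely a 2.8-fold higher number from compound 1 to compound 2 (0.45 log units; beyond the scatter), yet compounds 1 and 2 differ from compounds 3 and 4 elsewhere in the molecule as well, so the comparison is loose. That step was modest, and the present exchange of methyl for methylsulfanyl is a change of a like kind at the same kind of place. The expected outcome in this assay is therefore a step of at most modest size, most likely within the scatter, with a slight lean toward a higher number, which is the step meant by a 1.5-fold higher number from compound 3 to compound 4 (0.18 log units; within the scatter). Compound 4 is expected to give 6 nM, within a range from 2 nM to 18 nM.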

Compound 4, half-maximal inhibitory concentration: 5 nM
For compound 4 the middle estimate is 1.2-fold (0.08 log units) above the measured one, within the range that was stated.
By their numbers in this assay, from the lowest: compounds 3, 4 and 1 (each within the scatter of the next, the first and the last beyond it); then compound 2.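

In this assay, the exchange of methyl for methylsulfanyl on an aromatic carbon, ortho to a large group, gives a 1.3-fold higher number from compound 3 to compound 4 (0.10 log units; within the scatter), so the two groups cannot be told apart on this read-out. Among these compounds, this shows that the position accepts an added sulfur atom and a hydrogen-bond acceptor without a step beyond the scatter, something the only earlier step on this ring, a 2.8-fold higher number from compound 1 to compound 2 (0.45 log units; beyond the scatter), could not show, since those two compounds differ from compound 3 and compound 4 elsewhere in the molecule and carry other groups at this place. Nothing measured here explains why the two groups give such similar numbers.

Open, on these data alone, is whether methoxy, the oxygen counterpart of methylsulfanyl, would fall within the scatter of these two, and whether a longer chain such as ethylsulfanyl, an amine or a carboxylic acid would still be accepted at this place. Also open, as far as these compounds go, is how the same molecule with plain hydrogen at this place would compare with compound 3 and compound 4.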